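A larger amine side chain on the core of compound 1

The compounds below may be only part of what the source reports. "The series", "measured", "known", "first", "only" and "open" are said of these compounds alone.

Compound 1 `CCCCC(N)c1cc(C(F)(F)F)ccc1N1CCN(C(=O)CCc2ccc(Cl)cc2Cl)CC1`: 190 nM
Compound 2 `CC(C)C[C@H](N)c1cc(C(F)(F)F)ccc1N1CCN(C(=O)CCc2cccs2)CC1`: 4600 nM

In an assay on HEK293 cells for displacement of a labelled ligand from Melanocortin receptor 4 (Homo sapiens) (a higher number here means a weaker inhibitor, a lower number a stronger inhibitor), compound 1 gives 190 nM. Among the compounds with values here, that is the lower of the two numbers measured so far; the only other measured compound, compound 2, gives 4600 nM in this assay, and the gap between the two lies beyond the usual scatter. Compound 2 differs from compound 1 in more than one place, so its number cannot be traced to any single change.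

Compound 3 `CCC(C)CN[C@H](c1cc(C(F)(F)F)ccc1N1CCN(C(=O)CCc2ccc(Cl)cc2Cl)CC1)C(C)CC` differs from compound 1 in one place: 2-methyl-1-((2-methylbutyl)amino)butyl in place of 1-aminopentyl on an aromatic carbon. Within the data shown here, no measured pair shows this change, so there is no directly comparable step. The entering group has more heavy atoms than the one it replaces and carries a 2-methylbutyl chain on the nitrogen where compound 1 has a free amine. Going from a primary amine to a secondary one without any supporting measurement, the account expects a step toward a weaker inhibitor, a 3.2-fold higher number from compound 1 to compound 3 (0.50 log units; beyond the scatter), of modest size and with wide uncertainty. For compound 3 in this assay the estimate is 600 nM, with a likely range from 150 nM to 3000 nM.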

Compound 3, inhibition constant: 2800 nM
Beside the measured number, compound 3's estimate is 4.7-fold (0.67 log units) below it; low and high end bracket the measured number.
By their numbers in this assay, from the lowest: compound 1; then compounds 3 and 2 (each within the scatter of the next).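

Within the data shown here, putting 2-methyl-1-((2-methylbutyl)amino)butyl in place of 1-aminopentyl on this aromatic carbon gives a 15-fold higher number from compound 1 to compound 3 (1.17 log units; beyond the scatter) in this assay, a large step toward a weaker inhibitor and the only single-place comparison at this position. The earlier pair could not show this, since compound 1 and compound 2 differ in more than one place. The entering group is larger but has the same counts of hydrogen-bond donors and acceptors as the group it replaces, and nothing shown gives a reason for the weakening.

The compounds shown leave open whether the step belongs to the 2-methylbutyl chain on the nitrogen or to the altered carbon chain bearing that nitrogen. They also leave open how a methyl or ethyl group on that nitrogen would compare with the free amine of compound 1.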